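Series notes: amide replacement on a shared core, compound 4

The source may hold more compounds than are shown below. What is called first, only, known or untested is meant among the compounds shown, and "the series" means these compounds.

Measured so far in a functional assay on HUVEC cells (Homo sapiens) for inhibition, tested at 10 ug/mL; a higher number here means a stronger effect of the compound at the concentration tested, a lower number a weaker effect:
Compound 1, `COc1cc(/C=C/C(=O)c2cccc(NC(=O)c3c(Cl)cccc3Cl)c2)ccc1O`: 99%
Compound 2, `COc1cc(/C=C/C(=O)c2cccc(NC(=O)c3cccs3)c2)ccc1O`: 90%
Compound 3, `COc1cc(/C=C/C(=O)c2cccc(NC(=O)c3cc(Cl)cc(Cl)c3)c2)ccc1O`: 58%

Compound 3 stands lowest of the three numbers in this assay. Its nearest neighbour is compound 2, which lies beyond the scatter above it, and the furthest is compound 1. The two steps that reach compound 3 are both large: a number 41 percentage points lower from compound 1 to compound 3 (beyond the scatter) and a number 32 percentage points lower from compound 2 to compound 3 (beyond the scatter). Between the other two the difference is small, a number 9 percentage points lower from compound 1 to compound 2 (within the scatter), which lies within the scatter.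

Compound 4, `COc1cc(/C=C/C(=O)c2cccc(NC(=O)c3ccc(Cl)cc3)c2)ccc1O`, has not yet been measured in this assay. The change from compound 3 is 4-chlorophenyl in place of 3,5-dichlorophenyl on a carbonyl carbon. Among the compounds with values here, no measured step involves 4-chlorophenyl, so the only guidance is that both measured steps into compound 3, each ending in 3,5-dichlorophenyl on the carbonyl carbon, went strongly downward; leaving 3,5-dichlorophenyl again is therefore more likely to be followed by an upward step than by none, though the size is uncertain. Compound 4 is expected to give about 80% in this assay. For compound 4 the range is estimated as 55% to 100%. The expected step, a number 22 percentage points higher from compound 3 to compound 4 (beyond the scatter), is an estimate only.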

Compound 4, a percentage reported as inhibition, at one concentration (the size of the read-out at that concentration, not a potency): 66%
Estimate against measurement, compound 4: 14 percentage points above; low and high end bracket the measured number.
By their numbers in this assay, from the lowest: compounds 3 and 4 (each within the scatter of the next); then compounds 2 and 1 (each within the scatter of the next).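

The low read-out in this assay does not belong to 3,5-dichlorophenyl alone: with 4-chlorophenyl on the carbonyl carbon, the result is a number 8 percentage points higher from compound 3 to compound 4 (within the scatter) and the two compounds cannot be told apart. The 4-chlorophenyl amide also stays clearly separate from the two high compounds, with a number 24 percentage points lower from compound 2 to compound 4 (beyond the scatter) for thiophen-2-yl and a number 33 percentage points lower from compound 1 to compound 4 (beyond the scatter) for 2,6-dichlorophenyl, so the four compounds fall into a lower pair and an upper pair. Chlorine on the phenyl ring does not by itself place a compound in the lower pair, as compound 1 goes against that reading, and no measurement shown gives a reason for the split.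

Still open, going by these compounds, is whether a plain phenyl with no chlorine falls with the lower pair or the upper pair, and whether a furan-2-yl group behaves like thiophen-2-yl at this position. Also open, on these data alone, is how an amine or a carboxylic acid on the phenyl ring would read here, and whether the two pairs would stay apart at other concentrations, since each read-out comes from one concentration and is not a potency.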